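A few compounds are considered here, and "the series" means these few. Any claim that something is new, unique, unknown or untested is made for them only; others in the source may bear on it.

In a functional assay on HepG2 cells (Homo sapiens) for antiproliferative activity, read by MTT assay, with a stated time of 48 h (on this read-out higher numbers stand for weaker inhibition of growth and lower numbers for stronger inhibition of growth), compound 1 `COC(=O)N1N=C(c2cccc(OC)c2)CC1c1cc(OC)c(OC)c(OC)c1` gives 1870 nM, the lowest number shown. Compound 2 `CCOC(=O)N1N=C(c2cccc(OC)c2)CC1c1cc(OC)c(OC)c(OC)c1` gives 5820 nM. Compound 3 `COc1cccc(C2=NN(C(=O)OCc3ccccc3)C(c3cc(OC)c(OC)c(OC)c3)C2)c1` gives > 10000 nM, which is a limit of the assay. Compound 4 `COC(=O)N1N=C(c2cccc(O)c2)CC1c1cc(OC)c(OC)c(OC)c1` differs from compound 1 by hydrogen in place of methyl on an oxygen on an aromatic ring, turning methoxy to hydroxy. The measured changes, a 3.1-fold higher number from compound 1 to compound 2 (0.49 log units; beyond the scatter) and an at least 5.3-fold higher number from compound 1 to compound 3 (0.72 log units; beyond the scatter), both lie elsewhere on the molecule, so they offer only a scale for compound 1. On that scale, a modest rise is expected in this assay, though the direction is uncertain. The expected change is a 1.5-fold higher number from compound 1 to compound 4 (0.18 log units; within the scatter). The estimate for compound 4 is 2800 nM, within an expected range of 700 nM to 10000 nM.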

Compound 4, concentration for 50% growth inhibition: 650 nM
Beside the measured number, compound 4's estimate is 4.3-fold (0.63 log units) above it; measured number below the stated range.
By their numbers in this assay, from the lowest: compound 4; then compound 1; then compound 2. At a limit, above all of these: compound 3.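

In this assay, the step of a 2.9-fold lower number from compound 1 to compound 4 (0.46 log units; beyond the scatter), with hydrogen in place of methyl on an oxygen on an aromatic ring, shows that this part of the molecule also moves the number. Its direction is opposite to that of the two measured steps from compound 1, which lay elsewhere on the molecule. Nothing shown accounts for this step. On these data alone, whether an amine or an ethoxy group in place of the hydroxy would move the number the same way remains open. So does whether methoxy to hydroxy would give a similar step in compound 2.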